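Extending the Lipid Chain in Two Vanilloid Scaffolds

This account rests on a few compounds, and the source may have more. Where it says the series, first, only, none or still open, it means among the compounds named here.

Three compounds have been measured:
compound 1, `CCCCCCCCCCCCCCCC[Se]CCC(=O)NCc1ccc(O)c(OC)c1`, 4300 nM
compound 2, `CCCCCCCCCCCCCCCC(=O)N/N=C/c1ccc(O)c(OC)c1`, 280 nM
compound 3, `CCCCCCCC/C=C\CCCCCCCC[Se]CCC(=O)NCc1ccc(O)c(OC)c1`, 1800 nM

All were tested in an assay on HEK293 cells for antagonist activity at transient receptor potential cation channel subfamily V member 2 (Rattus norvegicus), read by fluorescence and calcium flux, with a stated time of 5 min; a higher number here means a weaker inhibitor, a lower number a stronger inhibitor. Compound 1 and compound 3 share a core; their difference is dec-1-en-1-yl in place of octyl on a saturated chain carbon, eight bonds along the chain from a selenium atom. That change gave a 2.4-fold lower number from compound 1 to compound 3 (0.38 log units; beyond the scatter). Compound 2 is built on a different core, and the difference between the two cores is not broken down here. In this assay compound 2 gives the lowest number of the three, beyond the scatter from both compound 1 and compound 3.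

Compound 4, `CCCCCCCC/C=C\CCCCCCCC(=O)N/N=C/c1ccc(O)c(OC)c1`, has not yet been measured. It relates to compound 2 as compound 3 relates to compound 1: the change is dec-1-en-1-yl in place of octyl on a saturated chain carbon, seven bonds along the chain from a carbonyl carbon. The two changes are the same kind of change but not the same, since in compound 1 the change sits eight bonds along the chain from a selenium atom, whereas in compound 2 it sits seven bonds along the chain from a carbonyl carbon.

Going by the values given here, the expected step from compound 2 to compound 4 is estimated at a 1.9-fold lower number from compound 2 to compound 4 (0.27 log units; within the scatter), resting on the single measured step from compound 1 to compound 3, a 2.4-fold lower number from compound 1 to compound 3 (0.38 log units; beyond the scatter), taken as a rough guide across the different core. For compound 4 in this assay the estimated value is 150 nM, expected to fall between 60 nM and 400 nM.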

Compound 4, half-maximal inhibitory concentration: 120 nM
Compound 4: middle estimate off by 1.3-fold (0.10 log units), on the high side, within the range that was stated.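

In this assay, swapping octyl for dec-1-en-1-yl on the core of compound 2 gave a 2.3-fold lower number from compound 2 to compound 4 (0.37 log units; beyond the scatter), and this step agrees with the one seen when the same swap was made on the selenium-containing core: the same change on two cores in this assay, a 2.4-fold lower number (0.38 log units; beyond the scatter) from compound 1 to compound 3 and a 2.3-fold lower number (0.37 log units; beyond the scatter) from compound 2 to compound 4, 1.0-fold (0.01 log units) apart, within the scatter of two such steps. For these two cores, then, the change carried over with its size intact, even though it sits at a different distance from the nearest landmark in each, eight bonds along the chain from a selenium atom in one and seven bonds along the chain from a carbonyl carbon in the other. Going by these compounds alone, this is only one change compared on two cores in one assay, so it does not show that the step would hold on any other core, and it does not say why the number falls, since the swap brings in extra carbon and a double bond together.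

On these data alone, what remains open is which of those two features carries the step, a question that a saturated decyl chain on either core could help to settle. Also open, as far as these compounds go, is how a still longer chain, or a chain ending in a carboxylic acid or an amine, would fare on these cores.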